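A few compounds are considered here, and "the series" means these few. Any claim that something is new, unique, unknown or untested is made for them only; others in the source may bear on it.

For the measured compounds named here, compound 1 `NS(=O)(=O)c1cccc(Nc2nccc(-c3ccncc3)n2)c1` gives 500 nM in a functional assay for inhibition, with Homo sapiens as the target (on this read-out higher numbers stand for weaker inhibition and lower numbers for stronger inhibition), and stands highest of the two numbers known so far. Its nearest neighbour, compound 2 `NS(=O)(=O)c1cccc(Nc2nccc(-c3cccnc3)n2)c1`, gives 200 nM in this assay; the change a 2.5-fold lower number from compound 1 to compound 2 (0.40 log units; beyond the scatter) is at the other ring and leaves the sulfamoyl group untouched. Compound 3 `Fc1cccc(Nc2nccc(-c3ccncc3)n2)c1` differs from compound 1 by fluoro in place of sulfamoyl on an aromatic carbon. Going by the values given here, no measured step touches this group, so the one known step gives no guide here. Compound 3 is therefore expected to give 1500 nM (range 300 nM to 8000 nM), a step of a 3.0-fold higher number from compound 1 to compound 3 (0.48 log units; beyond the scatter) that is an estimate only.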

Compound 3, half-maximal inhibitory concentration: 700 nM
Compound 3: middle estimate off by 2.1-fold (0.33 log units), on the high side, within the range that was stated.
By their numbers in this assay, from the lowest: compound 2; then compounds 1 and 3 (each within the scatter of the next).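

Putting fluoro in place of sulfamoyl on this aromatic carbon, meta to a large group, gives (a 1.4-fold higher number from compound 1 to compound 3 (0.15 log units; within the scatter)) in this assay. At this place, then, the sulfamoyl group, with its 4 heavy atoms and its hydrogen-bond donor, gives way to a single fluorine with no difference that stands clear of the scatter. Nothing available explains this result.

From the compounds shown here alone, whether an amine or a carboxylic acid at this place would fit the same picture remains open. So does whether fluoro would behave alike alongside the pyridin-3-yl group of compound 2.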